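From 4-methylbenzyl to 4-methoxybenzyl in compound 3

A few compounds are considered here, and "the series" means these few. Any claim that something is new, unique, unknown or untested is made for them only; others in the source may bear on it.

Compound 1 `COc1ccc(-n2c(SC)nnc2-c2cc(OC)c(OC)c(OC)c2)cc1` and compound 2 `COc1ccc(-n2c(SCc3ccc(C)cc3)nnc2-c2cc(OC)c(OC)c(OC)c2)cc1` share a core and have been tested in a functional assay on HepG2 cells (Homo sapiens) for inhibition, read by MTT assay, with a stated time of 48 h; a lower number here means a stronger inhibitor, a higher number a weaker inhibitor. In this assay compound 1 gives > 60000 nM, which is a limit of the assay and not a number. Going by the values given here, compound 2 gives 31600 nM, the only true number so far, so it cannot yet be ranked against a second measured value.

The next compound, compound 3 `COc1ccc(CSc2nnc(-c3cc(OC)c(OC)c(OC)c3)n2-c2ccc(OC)cc2)cc1`, carries methoxy in place of methyl on an aromatic carbon, para to a large group (methoxy in place of methyl on an aromatic carbon). This turns the 4-methylbenzyl group into 4-methoxybenzyl.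

Among the compounds with values here, only one measured step bears on this change, and only indirectly. That step, an at least 1.8-fold lower number from compound 1 to compound 2 (0.27 log units; that floor lies within the scatter), introduced the 4-methylphenyl group, and its floor lies within the scatter. Within the data shown here, no measured step exchanges methyl for methoxy, so no step beyond the scatter is expected in this assay, and no direction can be favoured. The estimated change is a 1.1-fold lower number from compound 2 to compound 3 (0.02 log units; within the scatter). Compound 3 is expected at about 30000 nM, with an estimated range from 12000 nM to 60000 nM.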

Compound 3, half-maximal inhibitory concentration: 41100 nM
Beside the measured number, compound 3's estimate is 1.4-fold (0.14 log units) below it; the measured number falls inside the stated range.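

In this assay, going by these compounds alone, methoxy in place of methyl on an aromatic carbon, para to a large group, gives a 1.3-fold higher number from compound 2 to compound 3 (0.11 log units; within the scatter); this is the first step with a true number at both ends, and it shows that this exchange leaves compound 3 within the scatter of compound 2. The other new step, an at least 1.4-fold lower number from compound 1 to compound 3 (0.16 log units; that floor lies within the scatter), gives only a floor, so that, like the earlier step that introduced the 4-methylphenyl group, it does not establish that a substituted benzyl group on the sulfur differs from the small group of compound 1. Compound 1 stands at a limit of the assay and not at a number, and that limit is all that sets the size of this floor: the limit of > 60000 nM in this assay, at which 1 of the 3 values shown sits.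

From the compounds shown here alone, what stays open is whether any group on this aromatic carbon moves the number beyond the scatter, as only methyl and methoxy stand there so far, and an amine or a carboxylic acid in that place would put this to the test. Also open, going by these compounds, is whether a longer chain between the sulfur and the aromatic ring changes the number at all.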